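A Bromophenyl Chalcone on the Shared Lactone Amide Core

The source may hold more compounds than are shown below. What is called first, only, known or untested is meant among the compounds shown, and "the series" means these compounds.

Of the compounds shown here, three with the shared core have been tested in a functional assay on PC-3 cells (Homo sapiens) for antiproliferative activity, read by MTT assay, with a stated time of 72 h; a lower number here means a stronger inhibitor, a higher number a weaker inhibitor. Compound 1 `CCOc1ccccc1OCCSC(=S)N[C@H]1CCOC1=O` gives 24100 nM. Compound 2 `COc1ccccc1/C=C/C(=O)c1ccc(OCC(=O)N[C@H]2CCOC2=O)cc1` gives 7240 nM, the lowest of the two numbers recorded, and the number for compound 1 stands above it by more than the usual scatter. Compound 3 `O=C(CNc1ccc(Cl)cc1Cl)N[C@H]1CCOC1=O` gives only > 64000 nM, which is a limit of the assay and not a number.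

The next compound, compound 4 `O=C(COc1ccc(C(=O)/C=C/c2ccc(Br)cc2)cc1)N[C@H]1CCOC1=O`, has not yet been measured in this assay. It differs from compound 2 in a single place: 4-bromophenyl in place of 2-methoxyphenyl on a double-bonded chain carbon bound to a double-bonded chain carbon. Within the data shown here, no pair of measured compounds shows an exchange of this kind, so the step has to be judged from compound 2 alone, without a measured precedent to lean on. Compound 4 is expected to give about 6000 nM, within a range from 2500 nM to 16000 nM. The expected step of a 1.2-fold lower number from compound 2 to compound 4 (0.08 log units; within the scatter) is small and is not expected to reach clearly beyond the scatter in either direction.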

Compound 4, half-maximal inhibitory concentration: > 64000 nM
Compound 4: only a limit was reported (the forecaster's own chance of this, stated with the estimate: 5%); middle value at least 10-fold (1.02 log units) from the limit.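

In this assay, the exchange of 2-methoxyphenyl for 4-bromophenyl on a double-bonded chain carbon bound to a double-bonded chain carbon gives an at least 8.8-fold higher number from compound 2 to compound 4 (0.94 log units; beyond the scatter), the first single-place step seen in this set, and it shows that the read-out depends on the group at this place even though both groups are six-membered aromatic rings of carbon only. Compound 4 gives > 64000 nM, which is a limit of the assay and not a number. The step therefore shows a clear loss, but its full size stays unknown: the limit of > 64000 nM in this assay, at which 2 of the 4 values shown sit.

The exchange changes both the atom attached to the ring and its place on the ring, so the compounds shown cannot separate these two changes. A 2-bromophenyl, a 4-methoxyphenyl or a plain phenyl at this place would help to tell them apart.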